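This account rests on a few compounds, and the source may have more. Where it says the series, first, only, none or still open, it means among the compounds named here.

Compound 2 `CCCc1nc(Br)c2cnnc(O)n12` was examined in a functional assay for inhibition, with Homo sapiens as the target; on this read-out lower numbers stand for stronger inhibition and higher numbers for weaker inhibition. In this assay compound 2 gives only a limit, > 48000 nM, and not a measured number. Compound 1 `C=CCSc1nncc2cnc(CCC)n12` also gives only a limit in this assay, > 48000 nM. Going by the values given here, both results sit at the limit of > 48000 nM in this assay, at which 2 of the 2 values shown sit, so compound 2 stands at the same limit as the one other value shown, with no number between the two to compare. Compound 3 `CCCc1ncc2cnnc(O)n12` differs from compound 2 by hydrogen in place of bromo on an aromatic carbon. Among the compounds with values here, no step between two measured compounds exists here, so the size of such a change cannot be read from the data. The expected step of a number no higher from compound 2 to compound 3 (the limit leaves the size open) is therefore essentially none beyond the scatter, with a limit again the most likely outcome. Compound 3 is estimated at 48000 nM, within a range from 20000 nM to 100000 nM.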

Compound 3, half-maximal inhibitory concentration: > 48000 nM
Compound 3: no number, only a limit; the forecaster's own chance of this, stated with the estimate: 85%; the middle value lies on the limit itself.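

Going by these compounds alone, compound 1, compound 2 and compound 3 all give only a limit, so no step among them can be read: the limit of > 48000 nM in this assay, at which 3 of the 3 values shown sit. The compounds shown leave open how strongly any of them inhibits, and whether changing the group on this aromatic carbon shifts the read-out at all.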